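The compounds below may be only part of what the source reports. "The series", "measured", "known", "first", "only" and "open" are said of these compounds alone.

Measured in a functional assay on the whole organism (strain Sprague-Dawley) for inhibition, with Rattus norvegicus as the target, with a stated time of 10 min; a lower number here means that less compound is needed, a higher number that more compound is needed for the effect:
- compound 1 `CCOc1ccccc1-c1ncc(C(=O)O)c(=O)[nH]1`: 0.5 mg/kg
- compound 2 `CCOC(=O)c1cnc(-c2ccccc2OC)[nH]c1=O`: 10 mg/kg
- compound 3 `CCOC(=O)c1cnc(-c2ccccc2OCC)[nH]c1=O`: 2 mg/kg

Compound 3 (2 mg/kg) holds the second highest of the three numbers, with compound 1 lower and compound 2 higher. The next compound, compound 4 `CCOC(=O)c1cnc(-c2ccccc2OCC2CC2)[nH]c1=O`, has cyclopropyl in place of methyl on a saturated chain carbon bound to an oxygen on an aromatic ring. The nearest evidence is the change at that same place, methyl in place of hydrogen, which gave a 5.0-fold lower number from compound 2 to compound 3 (0.70 log units; beyond the scatter), a modest step. The other step, a 4.0-fold higher number from compound 1 to compound 3 (0.60 log units; beyond the scatter), lies at the ethyl on an oxygen next to a carbonyl group, so it says little here. Within the data shown here, no measured compound carries a cyclopropyl group, and one favourable step does not show that the trend continues. The expected change is therefore small and within the scatter, with a 1.3-fold lower number from compound 3 to compound 4 (0.12 log units; within the scatter) expected in this assay and a slight lean towards a lower number. For compound 4 the estimated value is 1.5 mg/kg (expected range 0.4 mg/kg to 6 mg/kg).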

Compound 4, dose for 50% inhibition: 0.3 mg/kg
Compound 4: middle estimate off by 5.0-fold (0.70 log units), on the high side; the measured number lies below the stated range.
By their numbers in this assay, from the lowest: compounds 4 and 1 (each within the scatter of the next); then compound 3; then compound 2.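

In this assay, the favourable trend at this place did not stop at the ethoxy group: going to cyclopropylmethoxy gave a 6.7-fold lower number from compound 3 to compound 4 (0.82 log units; beyond the scatter), and the whole change from methoxy gave a 33-fold lower number from compound 2 to compound 4 (1.52 log units; beyond the scatter). The place on a saturated chain carbon bound to an oxygen on an aromatic ring thus accepts a three-membered ring of carbon, and the number still falls rather than levelling off. Nothing available gives a reason for the size of this step.

A straight propyl or a cyclobutyl group in the same place would show whether the gain belongs to the three-membered ring or simply to the added carbons. On these data alone, it also remains open whether cyclopropylmethoxy brings a similar step on the carboxylic acid of compound 1.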